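Triazole-linked aryl series: cytotoxicity working notes

The source may report more compounds than this note shows. Statements on the series, on what has been measured and on what is new or still open speak of the compounds shown alone.

Measured so far in a functional assay on MCF7 cells (Homo sapiens) for cytotoxicity, read by MTT assay, with a stated time of 4 days; a higher number here means a weaker inhibitor, a lower number a stronger inhibitor:
compound 1 `Cc1c(O)ccc2c1[C@H](Cn1cc(-c3ccc(F)cc3)nn1)[C@@]13CC(=O)[C@@](C)(CC[C@@H]21)C3`: > 20000 nM
compound 2 `Cc1c(O)ccc2c1[C@H](Cn1cc(-c3ccccn3)nn1)[C@@]13CC(=O)[C@@](C)(CC[C@@H]21)C3`: > 20000 nM
compound 3 `Cc1c(O)ccc2c1[C@H](Cn1cc(-c3ccc(C(F)(F)F)cc3)nn1)[C@@]13CC(=O)[C@@](C)(CC[C@@H]21)C3`: > 20000 nM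

Each of these values is a limit of the assay rather than a number. Compound 3 therefore stands only at a limit in this assay, and the two other values shown are limits as well; this is the situation described by the limit of > 20000 nM in this assay, at which 3 of the 3 values shown sit. The steps between the measured compounds, a step that the two limits leave unreadable from compound 1 to compound 2, a step that the two limits leave unreadable from compound 1 to compound 3 and a step that the two limits leave unreadable from compound 2 to compound 3, are all unreadable for the same reason, so no step size can be taken from them.

Compound 4 `Cc1ccc(-c2cn(C[C@H]3c4c(ccc(O)c4C)[C@@H]4CC[C@@]5(C)C[C@]43CC5=O)nn2)cc1` differs from compound 3 by methyl in place of trifluoromethyl on an aromatic carbon. Going by the values given here, none of the measured steps gives a readable size that bears on this change, and the three limits give no direction. Compound 4 is therefore expected to stay at the limit, an estimated 20000 nM with a range from 10000 nM to 40000 nM. The expected step from compound 3 is a number no higher from compound 3 to compound 4 (the limit leaves the size open), read against a limit, and the measurement will show whether compound 4 departs from it.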

Compound 4, half-maximal inhibitory concentration: > 20000 nM
Compound 4: no number, only a limit (the forecaster's own chance of this, stated with the estimate: 85%); the middle value lies on the limit itself.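

Compound 4 gives only a limit, > 20000 nM. The steps from compound 1, compound 2 and compound 3 to compound 4 therefore cannot be read: the limit of > 20000 nM in this assay, at which 4 of the 4 values shown sit.
The compounds shown leave open whether changing the aryl group on the shared core alters cytotoxicity at all.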